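Dihydropyridine aryloxyacetamides: paw edema inhibition, chlorothiophene regioisomer

The compounds below may be only part of what the source reports. "The series", "measured", "known", "first", "only" and "open" are said of these compounds alone.

Measured so far in a functional assay on the whole organism (strain Wistar) for inhibition, with Rattus norvegicus as the target, read by paw edema, with stated times of 30 min and 3 h, at a dose of 20 mg/kg; on this read-out lower numbers stand for less inhibition and higher numbers for more inhibition at the one dose given (going by the name of the read-out):
compound 1 `CCOC(=O)C1=C(C)NC(C)=C(C(=O)OCC)C1c1ccc(OCC(=O)Nc2c(C)cccc2C)cc1` gives 53.9%
compound 2 `CCOC(=O)C1=C(C)NC(C)=C(C(=O)OCC)C1c1ccc(OCC(=O)NNC(=O)c2sccc2Cl)cc1` gives 56.3%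

Compound 2 stands at the higher of the two numbers, with compound 1 a number 2.4 percentage points higher from compound 1 to compound 2 (within the scatter). The unmeasured compound 3 `CCOC(=O)C1=C(C)NC(C)=C(C(=O)OCC)C1c1ccc(OCC(=O)NNC(=O)c2ccsc2Cl)cc1` differs from compound 2 by 2-chlorothiophen-3-yl in place of 3-chlorothiophen-2-yl on a carbonyl carbon. For the measured compounds named here, no measured step covers this kind of change; the only step, from compound 1 to compound 2, is itself within the scatter and concerns a different group. For compound 3 no step beyond the scatter is therefore expected in this assay, neither up nor down, and the estimate is a number 1.3 percentage points lower from compound 2 to compound 3 (within the scatter). Compound 3 is thus expected to give about 55%, in the range 45% to 65%.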

Compound 3, a percentage reported as inhibition, in the whole organism at one dose (the size of the read-out at that dose, not a potency): 53.3%
Beside the measured number, compound 3's estimate is 1.7 percentage points above it; the measured number falls inside the stated range.
By their numbers in this assay, from the lowest: compounds 3, 1 and 2 (each within the scatter of the next).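

In this assay, 2-chlorothiophen-3-yl in place of 3-chlorothiophen-2-yl on a carbonyl carbon gives a number 3 percentage points lower from compound 2 to compound 3 (within the scatter), so this rearrangement of the same atoms does not separate the two compounds at this dose. Against the 2,6-dimethylphenyl amide, the reading is a number 0.6 percentage points lower from compound 1 to compound 3 (within the scatter), so the second chlorothiophene also stays level with it. Nothing available explains this flat response.

Whether the chlorine contributes remains open, as the compounds shown include no unsubstituted thiophene or bromothiophene on this carbonyl. As far as these compounds go, with a single dose, any potency difference also remains open.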